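Aryl exchange on the chain: compound 3 to compound 4

The source may report more compounds than this note shows. Statements on the series, on what has been measured and on what is new or still open speak of the compounds shown alone.

Compound 3 `COc1ccc(/C=C/C(=O)Nc2cc(C(=O)c3cc(OC)c(OC)c(OC)c3)cc(OC)c2OC)cc1N` gives 10100 nM in a functional assay on COLO 205 cells (Homo sapiens) for cytotoxicity, read by MTT assay, with a stated time of 72 h; a higher number here means a weaker inhibitor, a lower number a stronger inhibitor. Among the three measured compounds it holds the second highest number, but both neighbours lie within the scatter: compound 1 `COc1ccc(/C=C/C(=O)Nc2cc(C(=O)c3cc(OC)c(OC)c(OC)c3)ccc2OC)cc1` gives 10900 nM, and compound 2 `COc1ccc(C(=O)c2cc(OC)c(OC)c(OC)c2)cc1NC(=O)/C=C/c1cccc(OC(F)(F)F)c1` gives 7900 nM, so the three values cannot be ranked against one another.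

Compound 4 `COc1cc(C(=O)c2cc(OC)c(OC)c(OC)c2)cc(NC(=O)/C=C/c2cc(F)c(F)c(F)c2)c1OC` has not been measured. It differs from compound 3 by 3,4,5-trifluorophenyl in place of 3-amino-4-methoxyphenyl on a double-bonded chain carbon bound to a double-bonded chain carbon. Within the data shown here, one measured step touches the same place on the double-bonded chain carbon: a 1.4-fold lower number from compound 1 to compound 2 (0.14 log units; within the scatter). That exchange of one aryl for another left the number within the scatter. Among the measured compounds shown here, no measured compound carries the 3,4,5-trifluorophenyl at this place, and the rest of the series is unchanged between compound 3 and compound 4, so the only guide is that single precedent.

Because a 1.4-fold lower number from compound 1 to compound 2 (0.14 log units; within the scatter) stayed within the scatter, the expectation for the step from compound 3 to compound 4 in this assay is likewise no change beyond the scatter, a 1.2-fold lower number from compound 3 to compound 4 (0.07 log units; within the scatter), with the wider range reflecting the untested aryl. Compound 4 is therefore estimated at 8500 nM in this assay, expected to fall between 3000 nM and 25000 nM.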

Compound 4, half-maximal inhibitory concentration: 4300 nM
Compound 4: middle estimate off by 2.0-fold (0.30 log units), on the high side; low and high end bracket the measured number.
By their numbers in this assay, from the lowest: compounds 4, 2, 3 and 1 (each within the scatter of the next, the first and the last beyond it).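

In this assay, the exchange on a double-bonded chain carbon bound to a double-bonded chain carbon gives a 2.3-fold lower number from compound 3 to compound 4 (0.37 log units; beyond the scatter), a modest step and the only one shown at this place that leaves the scatter, whereas a 1.4-fold lower number from compound 1 to compound 2 (0.14 log units; within the scatter) stayed within it. Among these compounds, the aryl at this place can therefore shift the number in this assay, though only by a modest step so far, and the choice of aryl is not neutral in every pair. The leaving 3-amino-4-methoxyphenyl and the entering 3,4,5-trifluorophenyl both have 9 heavy atoms and one six-membered aromatic ring of carbon only, so the step comes with no difference in those counts, while the hydrogen-bond donor and acceptors of the leaving group are absent from the entering one; no supporting data bear on the reason for the step.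

The single exchange removes the amino and methoxy groups and brings in three fluorines together, so the compounds shown cannot assign the step to any one of these changes. Also open, going by these compounds, is how this place responds to an aryl carrying a single fluorine, a nitrile or a carboxylic acid, and whether 3,4,5-trifluorophenyl gives a similar step on the core of compound 1.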